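A few compounds are considered here, and "the series" means these few. Any claim that something is new, unique, unknown or untested is made for them only; others in the source may bear on it.

Compounds measured so far:
compound 1 `CC(=O)OCc1ccc2oc(=O)c(C(=O)Oc3cccc(Br)c3)cc2c1`: 21.8%
compound 2 `O=C(Oc1cccc(Br)c1)c1cc2cc([N+](=O)[O-])ccc2oc1=O`: 35.2%
compound 3 `NCc1ccc2oc(=O)c(C(=O)Oc3cccc(Cl)c3)cc2c1`: 86.6%

All three were tested in a functional assay on HT-1080 cells (Homo sapiens), read by transwell migration, with a stated time of 24 h, tested at 1 uM; a lower number here means a stronger effect, a higher number a weaker effect of the compound at the concentration tested. Compound 3 stands highest of the three numbers, which at this read-out means the weakest effect: compound 2 is nearest to it, and compound 1 furthest, both gaps beyond the scatter. Within the data shown here, the one step available between measured compounds that differ in a single place runs a number 13.4 percentage points higher from compound 1 to compound 2 (beyond the scatter), a modest change.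

Compound 4 `NCc1ccc2oc(=O)c(C(=O)Oc3cccc(Br)c3)cc2c1` is the next compound and has not yet been measured in this assay. It differs from compound 3 in this way: bromo in place of chloro on an aromatic carbon. Put one bond further out, the change reads 3-chlorophenyl to 3-bromophenyl; the chloro leaves and the bromo enters, with no change in ring count, donors, acceptors or charge.

Among the measured compounds shown here, no measured step bears directly on this change. The step from compound 1 to compound 2 concerns a different part of the shared core. Compounds 1 and 2 both carry the bromo on the phenyl ester, yet their numbers differ from that of compound 3 in the other groups as well, so no clean reading of the halogen swap can be drawn from them. The step of a number 6.6 percentage points lower from compound 3 to compound 4 (within the scatter) is therefore expected to be small, likely within the scatter. For compound 4 the expected number is 80%, in the range 55% to 100%.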

Compound 4, a percentage reported as activity, at one concentration (the size of the read-out at that concentration, not a potency): 79.3%
Estimate against measurement, compound 4: 0.7 percentage points above; the range from low to high includes it.
By their numbers in this assay, from the lowest: compound 1; then compound 2; then compounds 4 and 3 (each within the scatter of the next).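

In this assay the change from 3-chlorophenyl to 3-bromophenyl gives a number 7.3 percentage points lower from compound 3 to compound 4 (within the scatter) and so, with the aminomethyl group held in place, the two halogens cannot be told apart at this position on the aromatic ring. With the bromo held fixed, the other changed group on the shared core makes the large differences: nitro gives way to aminomethyl in a number 44.1 percentage points higher from compound 2 to compound 4 (beyond the scatter) and acetoxy gives way to amino on the saturated chain carbon in a number 57.5 percentage points higher from compound 1 to compound 4 (beyond the scatter) and both of these exceed the modest a number 13.4 percentage points higher from compound 1 to compound 2 (beyond the scatter) seen earlier. Nothing available accounts for why the halogen swap leaves the read-out within the scatter or why the amino-bearing group stands so far from the acetoxymethyl and nitro compounds.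

On these data alone, whether the halogen swap would read the same with acetoxymethyl or nitro in place of aminomethyl remains open, since those two groups appear here only with the bromo. Also open, as far as these compounds go, is how a fluoro or a methyl at the same place on the phenyl ester would read, and whether a longer chain carrying the amine, or a carboxylic acid in its place, would keep the number this high.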